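This account rests on a few compounds, and the source may have more. Where it says the series, first, only, none or still open, it means among the compounds named here.

Measured in a functional assay on the whole organism (strain Sprague-Dawley) for inhibition, with Rattus norvegicus as the target, with a stated time of 10 min; on this read-out lower numbers stand for an effect already at smaller amounts and higher numbers for an effect only at larger amounts of compound:
- Compound 1 `O=C(O)c1cnc(-c2ccccc2Cl)[nH]c1=O`: 5 mg/kg
- Compound 2 `O=C(O)c1cnc(-c2ccccc2OCC2CC2)[nH]c1=O`: 0.1 mg/kg

Compound 2, at 0.1 mg/kg, holds the lower of the two numbers in this assay. The next compound is compound 3 `O=C(O)c1cnc(-c2ccccc2OCc2ccccc2)[nH]c1=O`, which keeps the shared core and differs in a single group: phenyl in place of cyclopropyl on a saturated chain carbon bound to an oxygen on an aromatic ring. In words, this is phenyl in place of cyclopropyl on a saturated chain carbon bound to an oxygen on an aromatic ring. Going by the values given here, only one measured step bears on this change: a 50-fold lower number from compound 1 to compound 2 (1.70 log units; beyond the scatter), a large step beyond the scatter, made by putting cyclopropylmethoxy in place of chloro. Among the compounds with values here, no measured step alters the end of the chain itself, so the direction remains uncertain. A moderate move toward a higher number is expected, much smaller than that measured step. The expected change is a 3.0-fold higher number from compound 2 to compound 3 (0.48 log units; beyond the scatter). For compound 3 the estimated value is 0.3 mg/kg, with an expected range from 0.05 mg/kg to 2 mg/kg.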

Compound 3, dose for 50% inhibition: 5 mg/kg
Compound 3: the middle estimate sits 17-fold (1.22 log units) below what was measured, outside the stated range (above it).
By their numbers in this assay, from the lowest: compound 2; then compounds 1 and 3 (each within the scatter of the next).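

In this assay, the end of the ether chain proves decisive: phenyl in place of cyclopropyl gives a 50-fold higher number from compound 2 to compound 3 (1.70 log units; beyond the scatter), which cancels what a 50-fold lower number from compound 1 to compound 2 (1.70 log units; beyond the scatter) had brought. Benzyloxy in place of chloro on an aromatic carbon gives no change at the digits printed from compound 1 to compound 3 (within the scatter), so among these compounds an ether on that carbon does not bring a low number on its own, and only the cyclopropylmethoxy group does. Nothing available explains why the two chain ends differ so sharply.

Going by these compounds, it remains open whether the low number belongs to the three-membered ring as such or would also hold with a cyclobutyl or isopropyl end on the same chain. On these data alone, it is equally open whether a longer chain between the oxygen and the phenyl would move the number of compound 3.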